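Working notes: from compound 2 to compound 4

The source may hold more compounds than are shown below. What is called first, only, known or untested is meant among the compounds shown, and "the series" means these compounds.

The measured members of this series all carry a chain with a secondary amine, and the read-out followed here is a physicochemical assay for acid dissociation. Compound 1 `c1ccc(-c2ccc3c(NCCCNCc4ccco4)ccnc3c2)cc1` gives 9.47 in this assay. Compound 2 `COc1ccc(F)cc1CNCCCNc1ccnc2cc(C3CCCCC3)ccc12` gives 9.47, level with compound 1 at the digits shown. Compound 3 `CC(C)(C)c1ccc(Oc2ccc3c(NCCCNCc4ccco4)ccnc3c2)cc1` gives 9.28, which lies within the scatter of compound 2. Going by the values given here, no two measured compounds differ in a single place, so no step between measured compounds can be counted.

Compound 4 `COc1ccc(F)cc1CNCCCNc1ccnc2cc(Cc3ccc(F)cc3Cl)ccc12` is not yet measured. It differs from compound 2 in one place: 2-chloro-4-fluorobenzyl in place of cyclohexyl on an aromatic carbon. The change sits on the aromatic core and leaves the chain with its secondary amine untouched. Compound 3, which carries its own different group on that core, gives 9.28, within the scatter of compound 2, so variation at the core has so far not moved the number beyond the scatter. For the present change the expected movement is a number 0.02 log units lower from compound 2 to compound 4 (within the scatter), no more than the scatter in either direction. Compound 4 is estimated at 9.45, with a range from 9.1 to 9.8.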

Compound 4, acid dissociation constant: 9.47
Compound 4: middle estimate off by 0.02 log units, on the low side, and the stated range covers the measured number.
By their numbers in this assay, from the lowest: compounds 3, 1, 2 and 4 (each within the scatter of the next).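

Going by these compounds alone, the step of no change at the digits printed from compound 2 to compound 4 (within the scatter) in this assay is the first comparison between compounds that differ in one place, so this position can now be read directly rather than through compounds that also differ elsewhere. At this aromatic carbon, meta to a fused ring and para to a fused ring, a six-membered non-aromatic ring of carbon only gives way to 2-chloro-4-fluorobenzyl, which brings more heavy atoms, an aromatic ring, a fluorine and a chlorine, and the read-out stays within the scatter. No measurement is at hand that could explain this result.

From the compounds shown here alone, what a carboxylic acid or a piperidine ring would give at this aromatic carbon remains open, since cyclohexyl and 2-chloro-4-fluorobenzyl both count no hydrogen-bond donors, no hydrogen-bond acceptors and no net charge. Within the data shown here, it is also open whether 2-chloro-4-fluorobenzyl in place of cyclohexyl would read the same with a different group at the far end of the chain, such as the one in compound 1.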